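A few compounds are considered here, and "the series" means these few. Any claim that something is new, unique, unknown or untested is made for them only; others in the source may bear on it.

Compound 1 `ClCc1ccc(Cn2cnc3c(Cl)ncnc32)cc1` gives 13500 nM.
Compound 2 `ClCc1ccccc1Cn1cnc2ncnc(Cl)c21` gives 7070 nM.
Compound 3 `ClCc1ccc(Cn2cnc3c(Cl)nc(Cl)nc32)cc1` gives 8320 nM.

All three were tested in a functional assay on LOX IMVI cells (Homo sapiens) for cytotoxicity, read by sulforhodamine B assay, with a stated time of 48 h; on this read-out lower numbers stand for higher toxicity in this test and higher numbers for lower toxicity in this test. Compound 1 and compound 2 are built from the same atoms joined differently; the difference between the two cores is not broken down here. In this assay compound 2 gives 7070 nM, a value that lies within the usual scatter of the numbers for compound 1 and compound 3, so no order among the three can be claimed.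

Compound 3 differs from compound 1 in a single place: chloro in place of hydrogen on an aromatic carbon. The measured step for this change is a 1.6-fold lower number from compound 1 to compound 3 (0.21 log units; within the scatter), which is a small move that stays inside the range of repeated measurements.

Compound 4 `ClCc1ccccc1Cn1cnc2nc(Cl)nc(Cl)c21` has not yet been tested. It differs from compound 2 in one place: chloro in place of hydrogen on an aromatic carbon. The surroundings of the new chloro group are described in the same words for both pairs, so this is the same change already seen from compound 1 to compound 3, now made on the core of compound 2.

Going by the values given here, because the one measured instance of this change is a 1.6-fold lower number from compound 1 to compound 3 (0.21 log units; within the scatter), a step of similar size is expected here, namely a 1.4-fold lower number from compound 2 to compound 4 (0.15 log units; within the scatter). The value of compound 4 in this assay is therefore estimated at 5000 nM, with an expected range from 2500 nM to 10000 nM.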

Compound 4, concentration lethal to 50% of the cells: 720 nM
Compound 4: the middle estimate sits 6.9-fold (0.84 log units) above what was measured; measured number outside the range, below it.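

Putting chloro in place of hydrogen on an aromatic carbon, here between two ring nitrogen atoms, gives a 9.8-fold lower number from compound 2 to compound 4 (0.99 log units; beyond the scatter) in this assay, so on this core compound 4 is clearly more toxic in this test than its parent. Set beside the earlier pair, the same change does not carry over with the same size from one core to the other: the same change on two cores in this assay, a 1.6-fold lower number (0.21 log units; within the scatter) from compound 1 to compound 3 and a 9.8-fold lower number (0.99 log units; beyond the scatter) from compound 2 to compound 4, 6.1-fold (0.78 log units) apart, beyond the scatter of two such steps. This shows that, in these two pairs, the effect of this change depends on the core that carries it, so a step measured on one core was a poor guide to the step on the other; it does not show what in the cores is responsible, and two pairs are too few to give a rule for any further core in the series.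

The compounds shown leave open whether this large step belongs to chloro itself or whether another group on the same carbon, such as an amine or a methoxy group, would give a similar step on the core of compound 2. They also leave open whether the gap between the two cores would persist if the chloromethyl group were replaced by a plain methyl group.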